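Aryl exchange on the carbon double-bonded to nitrogen

The source may report more compounds than this note shows. Statements on the series, on what has been measured and on what is new or still open speak of the compounds shown alone.

Compound 2 `CS(=O)(=O)c1ccc(Cc2nnc3n2N=C(c2cc(Cl)sc2S(N)(=O)=O)CS3)cc1` carries the shared core with a 5-chloro-2-sulfamoylthiophen-3-yl group on a carbon with a double bond to nitrogen. In a functional assay on HT-29 cells (Homo sapiens) for cytotoxicity, read by MTT assay, with a stated time of 48 h, tested at 25 uM (a lower number here means a weaker effect, a higher number a stronger effect of the compound at the concentration tested), compound 2 gives 18.7%. Among the measured compounds shown here, the only other measured member is compound 1 `CS(=O)(=O)c1ccc(Cc2nnc3n2N=C(c2ccc(Cl)cc2Cl)CS3)cc1`, which in this assay gives 24.2%; the two values lie within the scatter of each other, so compound 2 stands level with compound 1 on the numbers so far.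

Compound 3 `CS(=O)(=O)c1ccc(Cc2nnc3n2N=C(c2ccc(O)c(C(N)=O)c2)CS3)cc1` differs from compound 2 in one place: 3-carbamoyl-4-hydroxyphenyl in place of 5-chloro-2-sulfamoylthiophen-3-yl on a carbon with a double bond to nitrogen. The ring on that carbon is exchanged once more, a six-membered aromatic ring of carbon only bearing the carbamoyl and hydroxy groups replacing the sulfamoyl-bearing thiophene.

For the measured compounds named here, one measured step bears on this, an exchange of the whole aryl at the same carbon from 2,4-dichlorophenyl to 5-chloro-2-sulfamoylthiophen-3-yl: a number 5.5 percentage points lower from compound 1 to compound 2 (within the scatter). Such an aryl swap left this assay essentially unchanged once, so no step beyond the scatter is expected here either, in either direction. Compound 3 is accordingly expected to give about 20% in this assay, within 8% to 34%, an expected step of a number 1.3 percentage points higher from compound 2 to compound 3 (within the scatter).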

Compound 3, a percentage reported as activity, at one concentration (the size of the read-out at that concentration, not a potency): 24.7%
Compound 3: the middle estimate sits 4.7 percentage points below what was measured; low and high end bracket the measured number.
By their numbers in this assay, from the lowest: compounds 2, 1 and 3 (each within the scatter of the next).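

In this assay, a third aryl group on the carbon with a double bond to nitrogen again fails to separate from the others: the result is a number 6 percentage points higher from compound 2 to compound 3 (within the scatter), and against the dichlorinated aryl it is a number 0.5 percentage points higher from compound 1 to compound 3 (within the scatter). The 3-carbamoyl-4-hydroxyphenyl, 5-chloro-2-sulfamoylthiophen-3-yl and 2,4-dichlorophenyl groups therefore stand level at this position, even though the set now includes both ring sizes and two different sets of substituents on a six-membered aromatic ring of carbon only. No accompanying measurement bears on why these three compounds stand level.

From the compounds shown here alone, what remains open is whether any group at this carbon can move the read-out beyond the scatter, for example a ring carrying a carboxylic acid or a primary amine, or a saturated cyclohexyl group in place of an aromatic ring. All three values come from one concentration, so they also leave open whether compound 1, compound 2 and compound 3 would show a stronger or weaker effect relative to one another at other concentrations.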